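The source may report more compounds than this note shows. Statements on the series, on what has been measured and on what is new or still open speak of the compounds shown alone.

Series notes, topoisomerase screen

Three compounds of this series have been run in an assay on isolated protein for inhibition of DNA topoisomerase 1 (Homo sapiens), tested at 100 uM; a higher number here means more inhibition at the concentration tested (going by the name of the read-out), a lower number less inhibition. Compound 1 `Cc1ccc2c(=O)n(C)c3c(c2c1)CCOc1ccccc1-3` and compound 2 `Cc1ccc2c3c(n(C)c(=O)c2c1)-c1ccccc1OCC3` share a fused core and differ in how that core is joined; in this assay compound 1 gives "not active" (no number reported), and compound 2 gives 11.9%. Compound 3 `COc1ccc(Cn2c(-c3ccccc3O)c(Br)c3ccccc3c2=O)cc1` is built on a different core and in this assay gives "not active" (no number reported). Compound 3 therefore stands without a single number; it is one of two entries in this assay for which no number is reported, compound 1 being the other, and only compound 2 carries a numerical reading.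

Compound 4 `COc1ccc(Cn2c(-c3ccccc3O)c(Br)c3cc(C)ccc3c2=O)cc1` is the next entry. It differs from compound 3 in one place: methyl in place of hydrogen on an aromatic carbon. No measured pair in the series shows what this methyl for hydrogen exchange does in this assay, so its size and direction cannot be read from a shown step. Compound 4 is expected to stay close to compound 3, whose reading is "not active" (no number reported), that is, near the bottom of the scale. The estimate for compound 4 in this assay is 8%, with a range from 0% to 25%, and a fair chance that again no number is reported.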

Compound 4, a percentage reported as inhibition, at one concentration (the size of the read-out at that concentration, not a potency): "not active" (no number reported)
The entry for compound 4 holds no number, so the estimate cannot be set against anything.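

In this assay compound 3 gives "not active" (no number reported) and compound 4 gives "not active" (no number reported) so no step can be read between these two compounds. The compounds shown leave open whether methyl in place of hydrogen on this aromatic carbon changes inhibition at all. No evidence bears on this result.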